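The source may report more compounds than this note shows. Statements on the series, on what has been measured and on what is new or still open speak of the compounds shown alone.

Measured compounds:
- compound 1, `Cc1cc(NCCN(C)C)nc2ccc(NC(=O)c3ccc(Cl)c(Cl)c3)cc12`: 2550 nM
- compound 2, `CCN1CCN(c2cc(C)c3cc(NC(=O)c4ccc(OC)cc4)ccc3n2)CC1`: 7690 nM

Of the compounds shown here, two have been tested in a functional assay on MCF7 cells (Homo sapiens) for antiproliferative activity, read by MTT assay, with a stated time of 72 h; a lower number here means a stronger inhibitor, a higher number a weaker inhibitor. Compound 1 gives 2550 nM in this assay. Compound 2 gives 7690 nM in this assay, the higher of the two numbers, so it is the weaker inhibitor of the pair, and the gap to compound 1 lies beyond the usual scatter. The two compounds differ in more than one place, so their values alone cannot be tied to any single structural feature.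

Compound 3, `CCN1CCN(c2cc(C)c3cc(NC(=O)c4ccccc4Cl)ccc3n2)CC1`, has not yet been measured in this assay. It keeps the core of compound 2 and changes only the group on the carbonyl carbon:

2-chlorophenyl in place of 4-methoxyphenyl on a carbonyl carbon

Among the measured compounds shown here, no measured pair shows this exact change, so the expected step rests on little. Given that compound 1, which also carries chlorine on its aromatic ring at the carbonyl, gives 2550 nM, a modest move toward a lower number is expected, though a result within the scatter would not surprise. The expected step in this assay is a 1.7-fold lower number from compound 2 to compound 3 (0.23 log units; within the scatter). Compound 3 is estimated at 4500 nM, with a likely range from 1500 nM to 14000 nM.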

Compound 3, half-maximal inhibitory concentration: > 50000 nM
Compound 3 ended at the assay's limit; the forecaster's own chance of this, stated with the estimate: 5%; at least 11-fold (1.04 log units) between middle value and limit.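

Exchanging 4-methoxyphenyl for 2-chlorophenyl on a carbonyl carbon, with the rest of the molecule kept, gives an at least 6.5-fold higher number from compound 2 to compound 3 (0.81 log units; beyond the scatter) in this assay. As far as these compounds go, compound 3 sits at a limit of the assay, which is not a number, so the true size of this step stays unknown: the limit of > 50000 nM in this assay, at which 1 of the 3 values shown sits. Among the compounds shown here, this is the first step between measured compounds that differ in one place, and it shows that the group on this carbonyl carbon can by itself move the result by more than the usual scatter, even when one substituted phenyl ring simply replaces another.

One pair cannot tell whether the change follows from losing the methoxy group, gaining the chlorine, or the place each holds on the ring, and a plain phenyl group with neither of them on this carbonyl carbon would help to separate these readings. From the compounds shown here alone, it also remains open whether a ring carrying an amine would be tolerated here, and whether the same exchange would have a similar effect on a compound with a different side chain on the shared core.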